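Aryl variation on the ring nitrogen of the shared core

A few compounds are considered here, and "the series" means these few. Any claim that something is new, unique, unknown or untested is made for them only; others in the source may bear on it.

Measured compounds:
- compound 1 `Cc1ccc(-n2cc(CN3C(=O)C[C@@H]4CC[C@@]3(C)C4(C)C)nn2)cc1`: 390 nM
- compound 2 `CC1(C)[C@H]2CC[C@]1(C)N(Cc1cn(-c3ccccc3)nn1)C(=O)C2`: 240 nM
- compound 3 `CC1(C)[C@H]2CC[C@]1(C)N(Cc1cn(-c3ccccc3Cl)nn1)C(=O)C2`: 220 nM

In a functional assay on SGC-7901 cells (Homo sapiens) for inhibition, read by MTT assay, with a stated time of 24 h (a higher number here means a weaker inhibitor, a lower number a stronger inhibitor), compound 1 gives the highest of the three numbers, yet its steps to the others are small: a 1.6-fold lower number from compound 1 to compound 2 (0.21 log units; within the scatter) and a 1.8-fold lower number from compound 1 to compound 3 (0.25 log units; within the scatter). The third step, a 1.1-fold lower number from compound 2 to compound 3 (0.04 log units; within the scatter), is likewise within the scatter. So far the aryl group on the ring nitrogen has not moved the read-out beyond repeat-measurement noise.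

Compound 4 `COc1cccc(-n2cc(CN3C(=O)C[C@@H]4CC[C@@]3(C)C4(C)C)nn2)c1` is not yet measured. Relative to compound 1 the change is 3-methoxyphenyl in place of 4-methylphenyl on an aromatic nitrogen. Both measured steps from compound 1 bear on it, since each also exchanges the substituent on that aryl ring, and both stayed within the scatter. A further change of the same kind is therefore expected to produce no step beyond the scatter in this assay, with no direction preferred.

The estimate for compound 4 is 300 nM, with a range of 150 nM to 600 nM, which corresponds to an expected step of a 1.3-fold lower number from compound 1 to compound 4 (0.11 log units; within the scatter).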

Compound 4, half-maximal inhibitory concentration: 590 nM
Beside the measured number, compound 4's estimate is 2.0-fold (0.29 log units) below it; the measured number falls inside the stated range.
By their numbers in this assay, from the lowest: compounds 3, 2, 1 and 4 (each within the scatter of the next, the first and the last beyond it).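

In this assay, going by these compounds alone, the aryl group on the aromatic nitrogen now produces steps beyond the scatter, both modest: a 2.5-fold higher number from compound 2 to compound 4 (0.39 log units; beyond the scatter) and a 2.7-fold higher number from compound 3 to compound 4 (0.43 log units; beyond the scatter) for the entry of 3-methoxyphenyl, whereas no step among compound 1, compound 2 and compound 3 left the scatter. The position is therefore not fully indifferent to the aryl group, although the change from 4-methylphenyl stays within the scatter (a 1.5-fold higher number from compound 1 to compound 4 (0.18 log units; within the scatter)), so compound 1 cannot be separated from either end of the series. Nothing available explains these steps.

Compound 4 alone carries a methoxy group, so the effect of that group cannot be separated from the place it occupies on the aryl ring. As far as these compounds go, how this position responds to an amine or a carboxylic acid on the aryl ring, or to a longer chain in place of the aryl group, remains open.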